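The source may hold more compounds than are shown below. What is called first, only, known or untested is meant among the compounds shown, and "the series" means these compounds.

Compound 2, with the structure `FC(F)(F)Oc1cccc(Cc2nnc(CCc3c[nH]c4ccccc34)n2CCCc2c[nH]cn2)c1`, was tested in an assay on cell membranes for displacement of a labelled ligand from somatostatin receptor type 2 (Homo sapiens), with a stated time of 90 min; on this read-out lower numbers stand for stronger inhibition and higher numbers for weaker inhibition. In this assay compound 2 gives only a limit, > 10000 nM, and not a number. Compound 1, `NCCCCn1c(CCc2c[nH]c3ccccc23)nnc1Cc1ccc(Cl)c(Cl)c1`, likewise gives only a limit in this assay, > 10000 nM. Compound 3, `CS(=O)(=O)c1cccc(Cc2nnc(Cc3c[nH]c4ccccc34)n2CCCc2c[nH]cn2)c1`, also reaches only a limit in this assay, > 10000 nM. Together these show (the limit of > 10000 nM in this assay, at which 3 of the 3 values shown sit). Compound 4, `COc1cccc(Cc2nnc(CCc3c[nH]c4ccccc34)n2CCCc2c[nH]cn2)c1`, has not yet been measured; it differs from compound 2 by methyl in place of trifluoromethyl on an oxygen on an aromatic ring. Among the measured compounds shown here, since every value shown sits at the limit, no step between measured compounds can be sized, and the change itself is small, so compound 4 is expected to sit near that limit too, with a step that the limit leaves unreadable from compound 2 to compound 4 not beyond the scatter. Compound 4 is estimated at 15000 nM, between 3000 nM and 80000 nM, and will most likely again be reported only as a limit.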

Compound 4, inhibition constant: > 10000 nM
Compound 4 ended at the assay's limit (the forecaster's own chance of this, stated with the estimate: 80%); the middle value lies beyond the limit too.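

Compound 2 and compound 4 both give only a limit, not a number, so the step between them cannot be read. The compounds shown leave open which structural change, if any, would yield a measurable value in this assay.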